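Replacing Isopropyl with 2-Hydroxyethyl in Compound 2

The compounds below may be only part of what the source reports. "The series", "measured", "known", "first", "only" and "open" are said of these compounds alone.

Compound 1 `O=C1C2=C(CCCC2)S(=O)(=O)N1c1ccc(F)cc1`: 4100 nM
Compound 2 `CC(C)OC(=O)C1=CCCCC1S(=O)(=O)Nc1ccc(F)cc1F`: 110 nM

Of the compounds shown here, two have been measured in a functional assay on RAW264.7 cells (Mus musculus) for inhibition; on this read-out lower numbers stand for stronger inhibition and higher numbers for weaker inhibition. Compound 2 holds the lower number of the pair at 110 nM, and the gap to compound 1 at 4100 nM lies beyond the scatter. The two differ in more than one place, so their values offer no guide to any single change.

Compound 3 `O=C(OCCO)C1=CCCCC1S(=O)(=O)Nc1ccc(F)cc1F` has yet to be measured. It carries 2-hydroxyethyl in place of isopropyl on an oxygen next to a carbonyl group. Among the compounds with values here, no measured pair shows this change, so the expectation is a judgement anchored only on compound 2 at 110 nM. A moderate loss of inhibition beyond the scatter is expected, and the estimated move is a 4.1-fold higher number from compound 2 to compound 3 (0.61 log units; beyond the scatter). For compound 3 the expected value in this assay is 450 nM, with an estimated range of 120 nM to 1800 nM.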

Compound 3, half-maximal inhibitory concentration: 330 nM
The estimate for compound 3 lay 1.4-fold (0.13 log units) above the measured number; the range from low to high includes it.
By their numbers in this assay, from the lowest: compound 2; then compound 3; then compound 1.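

Within the data shown here, this is the first change read in one place, and it shows that this assay responds to the group on this oxygen: putting 2-hydroxyethyl in place of isopropyl gives a 3.0-fold higher number from compound 2 to compound 3 (0.48 log units; beyond the scatter), a modest loss of inhibition. The loss is only partial, as compound 3 still gives 330 nM. No measurement shown here accounts for the step.

The compounds shown leave open which part of the change matters, the terminal hydroxyl or the replacement of the branched isopropyl by a straight chain, and a plain ethyl or n-propyl group and a 2-methoxyethyl group on this oxygen would bear on that question. From the compounds shown here alone, how a longer chain, a terminal amine or the free carboxylic acid would behave at this position also remains open.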